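The source may hold more compounds than are shown below. What is called first, only, known or untested is meant among the compounds shown, and "the series" means these compounds.

Measured so far:
compound 1 `COc1cc(C(=O)N/N=C/c2ccc(F)c(F)c2)cc(OC)c1OC` — 43.7%
compound 2 `COc1cc(C2=NN(C(C)=O)C(c3ccccc3C(F)(F)F)O2)cc(OC)c1OC` — 15.2%
compound 3 `COc1ccc(OC)c(/C=N/NC(=O)c2cc(OC)c(OC)c(OC)c2)c1` — 51.7%

In a functional assay on PC-3 cells (Homo sapiens) for antiproliferative activity, read by MTT assay, tested at 5 uM (on this read-out higher numbers stand for a stronger effect at the one concentration tested and lower numbers for a weaker effect), compound 2 gives 15.2% and stands lowest of the three numbers. Compound 1 gives 43.7%, which lies above compound 2 by a gap beyond the scatter; compound 3 gives 51.7%, the furthest from compound 2, again beyond the scatter. Among the compounds with values here, compound 1 and compound 3 are built on a different core from compound 2, so these gaps combine several changes at once and no single-change step exists among the measured compounds.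

Compound 4 `COc1cc(C2=NN(C(C)=O)C(c3cccc(C(F)(F)F)c3)O2)cc(OC)c1OC` keeps the core of compound 2 and changes only one thing: 3-(trifluoromethyl)phenyl in place of 2-(trifluoromethyl)phenyl on a saturated ring carbon. The trifluoromethyl group stays on the same phenyl ring and the ring stays on the same saturated ring carbon, next to the ring nitrogen and next to the ring oxygen. Within the data shown here, no measured pair isolates a shift of this kind, so the size of the step has to be taken as uncertain; a shift of one substituent around a phenyl ring on an otherwise unchanged core is expected to give a small step, with no clear direction, and most likely one that stays within the scatter.

In this assay compound 4 is therefore expected to give about 20%, within a range from 5% to 40%. The step of a number 4.8 percentage points higher from compound 2 to compound 4 (within the scatter) is estimated to be no larger than the scatter.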

Compound 4, a percentage reported as inhibition, at one concentration (the size of the read-out at that concentration, not a potency): 43.6%
Beside the measured number, compound 4's estimate is 23.6 percentage points below it, and the stated range ends below it.
By their numbers in this assay, from the lowest: compound 2; then compounds 4, 1 and 3 (each within the scatter of the next).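

In this assay, the series now has its first single-change step: moving the trifluoromethyl group around the phenyl ring on the saturated ring carbon gives a number 28.4 percentage points higher from compound 2 to compound 4 (beyond the scatter). Within the data shown here, the activity of this core therefore responds to where this one group sits on the phenyl ring, even with the core and the atoms unchanged, which the earlier compounds, with their differing cores, could not show. The 2-(trifluoromethyl)phenyl and 3-(trifluoromethyl)phenyl groups have the same heavy-atom composition and the same counts of hydrogen-bond donors and acceptors, so these counts do not separate compound 2 from compound 4, and no measurement available here accounts for the step.

As far as these compounds go, it remains open whether the same shift would give a step of this size with a methyl group, a chlorine atom or a carboxylic acid on the phenyl ring in place of trifluoromethyl. From the compounds shown here alone, it is equally open whether the step would hold if the acetyl group on the neighbouring ring atom gave way to a longer acyl chain such as butanoyl.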